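From 3-hydroxyphenyl to 4-methoxyphenyl on the shared core

The compounds below may be only part of what the source reports. "The series", "measured", "known", "first", "only" and "open" are said of these compounds alone.

Of the compounds shown here, three with the same core have been measured in an ADME assay on a cell-free system (plasma, Rattus norvegicus) for metabolic stability, read by LC-MS, with a stated time of 1 h, tested at 100 uM; a higher number here means that more of the compound is left, a lower number that less of the compound is left. Compound 1 `CC1=C(c2nc(-c3ccc(C#N)cc3)cs2)C(c2cc3ccccc3n2C)NC(=O)N1` gives 95.6%, compound 2 `CC1=C(c2nc(-c3ccc(C#N)cc3)cs2)C(c2ccc(Cl)nc2)NC(=O)N1` gives 91.7%, and compound 3 `CC1=C(c2nc(-c3ccc(C#N)cc3)cs2)C(c2cccc(O)c2)NC(=O)N1` gives 88.5%. The values do not set compound 3 apart from either of the others: the steps are a number 7.1 percentage points lower from compound 1 to compound 3 (within the scatter) and a number 3.2 percentage points lower from compound 2 to compound 3 (within the scatter).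

Compound 4 `COc1ccc(C2NC(=O)NC(C)=C2c2nc(-c3ccc(C#N)cc3)cs2)cc1` has 4-methoxyphenyl in place of 3-hydroxyphenyl on a saturated ring carbon. Among the measured compounds shown here, no measured step makes this exact exchange, and no measured compound carries 4-methoxyphenyl. For the measured compounds named here, all the measured steps do change the group at this same ring carbon, however. Besides the two steps above, the third is a number 3.9 percentage points lower from compound 1 to compound 2 (within the scatter). These exchanges among 1-methyl-1H-indol-2-yl, 6-chloropyridin-3-yl and 3-hydroxyphenyl all stayed within the scatter in this assay, so no shift beyond the scatter is expected here and no direction can be favoured. The expected step is a number 1.5 percentage points higher from compound 3 to compound 4 (within the scatter), which would be no real change. For compound 4 the estimated value is 90%, with an expected range from 80% to 98%.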

Compound 4, percent of the compound remaining: 96%
For compound 4 the middle estimate is 6 percentage points below the measured one; measured number inside the range.
By their numbers in this assay, from the lowest: compounds 3, 2, 1 and 4 (each within the scatter of the next).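

In this assay, 4-methoxyphenyl joins the groups on this saturated ring carbon without a shift beyond the scatter against any of them: a number 7.5 percentage points higher from compound 3 to compound 4 (within the scatter), a number 4.3 percentage points higher from compound 2 to compound 4 (within the scatter), and a number 0.4 percentage points higher from compound 1 to compound 4 (within the scatter). The earlier compounds shown here showed this only among 1-methyl-1H-indol-2-yl, 6-chloropyridin-3-yl and 3-hydroxyphenyl; the four compounds now show it for a fourth group, and the exchange of 3-hydroxyphenyl, with its hydrogen-bond donor, for 4-methoxyphenyl, with none, also stays within the scatter. Nothing available gives a reason why the four numbers stay so close.

All the groups compared so far at this position carry an aromatic ring, so the compounds shown leave open whether a group such as an aminomethyl, a carboxylic acid or a longer alkyl chain on this ring carbon would also stay within the scatter. They also leave open how far the read-out depends on the rest of the shared core, for instance if a carboxylic acid stood in place of the nitrile, since every compound here carries that same part.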